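The source may hold more compounds than are shown below. What is called first, only, known or untested is meant among the compounds shown, and "the series" means these compounds.

Compound 2 `Nc1cc(N)c2nc(-c3ccccc3)c(NCc3ccc(F)cc3)nc2c1` and compound 1 `Nc1cc(N)c2nc(-c3ccccc3)c(Oc3ccc(Cl)c(Cl)c3)nc2c1` share the core and differ only at one aromatic carbon. In a functional assay on MOLT-4 cells (Homo sapiens) for inhibition, read by sulforhodamine B assay, with a stated time of 48 h (a higher number here means a weaker inhibitor of growth, a lower number a stronger inhibitor of growth), compound 1 gives only a limit, < 100000 nM. In this assay compound 2 likewise gives only a limit, < 100000 nM. The step from compound 1 to compound 2 is therefore a step that the two limits leave unreadable from compound 1 to compound 2, and nothing about its size can be read. Both values sit at the limit of < 100000 nM in this assay, at which 2 of the 2 values shown sit, so compound 2 stands nowhere fixed on the scale, only on the side that the limit marks. Compound 3 `COc1ccc(Sc2nc3cc(N)cc(N)c3nc2-c2ccccc2)cc1` is not yet measured; compared with compound 2 the change is (4-methoxyphenyl)sulfanyl in place of (4-fluorobenzyl)amino on an aromatic carbon. Within the data shown here, no measured step bears on a change of this kind, since the only step is unreadable. With only limits to go on, compound 3 is expected to stay near the same limit, with a step from compound 2 to compound 3 of about a step that the limit leaves unreadable from compound 2 to compound 3. The estimate for compound 3 in this assay is 40000 nM, within the range 8000 nM to 100000 nM.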

Compound 3, concentration for total growth inhibition: < 100000 nM
Compound 3: no number, only a limit; the forecaster's own chance of this, stated with the estimate: 50%; the middle value lies beyond the limit too.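

In this assay, among these compounds, compound 3 gives only a limit, so no step linking it to compound 1 or compound 2 can be read: the limit of < 100000 nM in this assay, at which 3 of the 3 values shown sit.
The compounds shown leave open where each lies on the scale and whether exchanging the group on this aromatic carbon alters growth inhibition.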